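From an Ether-Bearing Ring to a Methylpyrimidine

The source may hold more compounds than are shown below. What is called first, only, known or untested is meant among the compounds shown, and "the series" means these compounds.

In an ADME assay on microsomes from liver (Rattus norvegicus) for metabolic stability (on this read-out higher numbers stand for a longer-lived compound and lower numbers for a shorter-lived compound), compound 1 (`CC#C[C@@H](Cc1nnn[nH]1)c1ccc(OCc2ccc3scc(-c4cccnc4C)c3c2)cc1`) gives 0.183 h, compound 2 (`CC#C[C@@H](Cc1nnn[nH]1)c1ccc(OCc2ccc3scc(-c4cc(OCCOC)ccc4C)c3c2)cc1`) gives 0.367 h and compound 3 (`CC#C[C@@H](Cc1nnn[nH]1)c1ccc(OCc2ccc3sc(C#N)c(-c4ccccc4C)c3c2)cc1`) gives 0.533 h. Compound 2 holds the middle of these three numbers, yet its gaps to compound 1 and to compound 3 both lie within the usual scatter.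

Compound 4 (`CC#C[C@@H](Cc1nnn[nH]1)c1ccc(OCc2ccc3scc(-c4cncnc4C)c3c2)cc1`) differs from compound 2 in one place: 4-methylpyrimidin-5-yl in place of 5-(2-methoxyethoxy)-2-methylphenyl on an aromatic carbon. Within the data shown here, one measured step touches that same place, namely a 2.0-fold higher number from compound 1 to compound 2 (0.30 log units; within the scatter). That step links 2-methylpyridin-3-yl with the 5-(2-methoxyethoxy)-2-methylphenyl group that compound 4 gives up, and it is no larger than the scatter. Compound 3 differs from compound 2 in more than one place, so it offers no clean comparison. Among the measured compounds shown here, no compound with a pyrimidine has been measured yet, which leaves compound 1, at 0.183 h, as the closest guide, since its 2-methylpyridin-3-yl group resembles 4-methylpyrimidin-5-yl more than the group that leaves does. The estimated step is a 1.3-fold lower number from compound 2 to compound 4 (0.12 log units; within the scatter), expected to be slightly downward and not beyond the scatter. Compound 4 is therefore expected at 0.28 h, with an estimated range from 0.14 h to 0.56 h.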

Compound 4, half-life: 0.333 h
Compound 4: the middle estimate sits 1.2-fold (0.08 log units) below what was measured; the range from low to high includes it.
By their numbers in this assay, from the lowest: compounds 1, 4, 2 and 3 (each within the scatter of the next, the first and the last beyond it).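

In this assay, putting 4-methylpyrimidin-5-yl with 7 heavy atoms in place of 5-(2-methoxyethoxy)-2-methylphenyl with 12 heavy atoms gives a 1.1-fold lower number from compound 2 to compound 4 (0.04 log units; within the scatter) and so leaves the reading indistinguishable, even though the ether-bearing chain is gone and the ring now holds 2 hetero atoms. The pyrimidine cannot be told apart from the pyridine either, with a 1.8-fold higher number from compound 1 to compound 4 (0.26 log units; within the scatter) in this assay, so all three groups tried on this aromatic carbon, two ring bonds from the ring sulfur, lie within the scatter of one another. Nothing measured here points to what lies behind these readings.

These three groups therefore do not show whether this position can shift the half-life beyond the scatter at all, and a ring carrying an amine or a carboxylic acid, or a chain longer than 2-methoxyethoxy, could test that. The nitrile of compound 3 also stays unresolved, as that compound differs from the others in more than one place and its contribution cannot be read alone.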